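Chloro in place of boronic acid on the anilino ring

The compounds below may be only part of what the source reports. "The series", "measured", "known", "first", "only" and "open" are said of these compounds alone.

Measured so far:
compound 1 `CCOc1ccc(Br)cc1-c1cc(Nc2ccc(B(O)O)cc2)nc(N)n1` with 200 nM
compound 2 `Nc1nc(Nc2ccc(Cl)cc2)cc(-c2cc(Cl)ccc2Cl)n1` with limit < 100 nM
compound 3 `CCOc1ccc(Cl)cc1-c1cc(Nc2ccc3c[nH]nc3c2)nc(N)n1` with limit < 100 nM

Among the compounds with values here, in a functional assay on K562 cells (Homo sapiens) for inhibition (a higher number here means a weaker inhibitor, a lower number a stronger inhibitor), compound 1 gives 200 nM, the only full number among the three. Compound 2 is reported only as a limit of the assay, < 100 nM. Compound 3 is likewise only a limit, < 100 nM. Within the data shown here, compound 1 thus carries the sole number, while the two other values sit at the limit of < 100 nM in this assay, at which 2 of the 3 values shown sit.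

Compound 4 `CCOc1ccc(Br)cc1-c1cc(Nc2ccc(Cl)cc2)nc(N)n1` is not yet measured. It differs from compound 1 by one chlorine atom in place of a group of 3 heavy atoms (1 boron, 2 oxygen; no ring), on an aromatic carbon. Among the measured compounds shown here, no measured pair shows this exact change. Compound 2 bears the same chloro-substituted anilino group and gives only the limit < 100 nM, so a gain beyond the scatter is expected. Compound 4 is therefore expected near 70 nM, within 25 nM to 200 nM. The expected step is a 2.9-fold lower number from compound 1 to compound 4 (0.46 log units; beyond the scatter), with a fair chance that only a limit is reported.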

Compound 4, half-maximal inhibitory concentration: 50 nM
The estimate for compound 4 lay 1.4-fold (0.15 log units) above the measured number; low and high end bracket the measured number.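

Chloro in place of the group of 3 heavy atoms (1 boron, 2 oxygen), on an aromatic carbon para to a large group, gives in this assay a 4.0-fold lower number from compound 1 to compound 4 (0.60 log units; beyond the scatter). At this position, then, inhibition in the cells does not depend on the hydrogen-bond donors and acceptors of the leaving group, as chloro has none. Compounds 2 and 3 remain limits and give no step: the limit of < 100 nM in this assay, at which 2 of the 4 values shown sit.

This single pair cannot show whether the gain is specific to chloro. An amine, a carboxylic acid or a methyl at this position would test that.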